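This account rests on a few compounds, and the source may have more. Where it says the series, first, only, none or still open, it means among the compounds named here.

Measured so far, in a functional assay on MCF7 cells (Homo sapiens) for cytotoxicity, read by MTT assay, with a stated time of 72 h; on this read-out lower numbers stand for stronger inhibition and higher numbers for weaker inhibition:
compound 1 `CNC(=O)c1cc(Oc2ccc(C(=O)/C=C/c3cccc(Br)c3)cc2)ccn1` gives 10400 nM;
compound 2 `CNC(=O)c1cc(Oc2ccc(C(=O)/C=C/c3ccc(F)cc3Cl)cc2)ccn1` gives 21100 nM.

Among the compounds with values here, compound 1 carries the lower of the two numbers, and the single step observed is a 2.0-fold higher number from compound 1 to compound 2 (0.31 log units; beyond the scatter). Compound 3 `CNC(=O)c1cc(Oc2ccc(C(=O)/C=C/c3ccc(C#N)cc3)cc2)ccn1` has not yet been tested. It differs from compound 1 in one place: 4-cyanophenyl in place of 3-bromophenyl on a double-bonded chain carbon bound to a double-bonded chain carbon. Within the data shown here, no measured pair exchanges a 3-bromophenyl for a 4-cyanophenyl, so the only guide is the step from compound 1 to compound 2, which showed that changing the halogen pattern on this ring shifted the number only modestly. A shift of similar size, in either direction, is the most that is expected here, and it could well fall within the scatter. Compound 3 is therefore estimated at 12000 nM, with a range from 4000 nM to 36000 nM, meaning an expected step of a 1.2-fold higher number from compound 1 to compound 3 (0.06 log units; within the scatter).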

Compound 3, half-maximal inhibitory concentration: 9520 nM
Compound 3: the middle estimate sits 1.3-fold (0.10 log units) above what was measured; low and high end bracket the measured number.
By their numbers in this assay, from the lowest: compounds 3 and 1 (each within the scatter of the next); then compound 2.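

In this assay, a 4-cyanophenyl on this double-bonded chain carbon can stand in for the 3-bromophenyl, with a 1.1-fold lower number from compound 1 to compound 3 (0.04 log units; within the scatter). Set against the 2-chloro-4-fluorophenyl, the same ring gives a 2.2-fold lower number from compound 2 to compound 3 (0.35 log units; beyond the scatter), so a ring with a nitrile and no halogen serves here as well as the bromine-bearing ring of compound 1, and compound 2 alone stands beyond the scatter from the other two. Nothing beyond these cell numbers is available to explain why the rings compare in this way.

Compound 1 and compound 3 differ in both the group on the ring and its place, so a 4-bromophenyl or a 3-cyanophenyl would be needed to separate those two changes. Also open, going by these compounds, is whether an amine or a carboxylic acid on this ring would move the number further in either direction.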